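A few compounds are considered here, and "the series" means these few. Any claim that something is new, unique, unknown or untested is made for them only; others in the source may bear on it.

Of the compounds shown here, two have been measured in a functional assay on BT-549 cells (Homo sapiens) for inhibition; a lower number here means a stronger inhibitor of growth, a higher number a weaker inhibitor of growth. Compound 1 `COc1cc(/C=C/C(=O)c2cccc(-n3cc(-c4ccc(Cl)cc4)[nH]c3=O)c2)cc(OC)c1OC` gives 12300 nM. Compound 2 `COc1ccc(-c2cn(-c3cccc(C(=O)/C=C/c4ccc(O)c(OC)c4)c3)c(=O)[nH]2)cc1` gives 4570 nM, the lower of the two numbers, a gap beyond the usual scatter. Compound 3 `COc1ccc(-c2cn(-c3cccc(C(=O)/C=C/c4cc(OC)c(OC)c(OC)c4)c3)c(=O)[nH]2)cc1` is compound 2 with one change: 3,4,5-trimethoxyphenyl in place of 4-hydroxy-3-methoxyphenyl on a double-bonded chain carbon bound to a double-bonded chain carbon. Going by the values given here, no measured pair shows this change on its own, so the direction is uncertain; compound 1 also carries a 3,4,5-trimethoxyphenyl but differs from compound 2 elsewhere too. A moderate weakening is expected, giving a 2.0-fold higher number from compound 2 to compound 3 (0.29 log units; within the scatter). Compound 3 is therefore estimated at 9000 nM, within a range from 3000 nM to 30000 nM.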

Compound 3, concentration for 50% growth inhibition: 2590 nM
Compound 3: the middle estimate sits 3.5-fold (0.54 log units) above what was measured; measured number below the stated range.
By their numbers in this assay, from the lowest: compounds 3 and 2 (each within the scatter of the next); then compound 1.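

In this assay, 3,4,5-trimethoxyphenyl in place of 4-hydroxy-3-methoxyphenyl gives a 1.8-fold lower number from compound 2 to compound 3 (0.25 log units; within the scatter) and so compound 2 and compound 3 cannot be told apart, even though the entering group has no hydrogen-bond donor. Holding 3,4,5-trimethoxyphenyl fixed also isolates a second place for the first time: methoxy in place of chloro on an aromatic carbon gives a 4.7-fold lower number from compound 1 to compound 3 (0.68 log units; beyond the scatter) and this modest step is the only single-change step here that lies beyond the scatter. As far as these compounds go, how an amine or a carboxylic acid would behave on that aromatic carbon remains open. No measurement here explains either step.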